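This account rests on a few compounds, and the source may have more. Where it says the series, first, only, none or still open, it means among the compounds named here.

Measured so far:
Compound 1, `CC(C)NC1CC(=O)N(c2ccc(F)c(Cl)c2)C1OCC(F)(F)F`, in a functional assay on A549 cells (Homo sapiens) for inhibition (a higher number here means a weaker inhibitor, a lower number a stronger inhibitor), gives > 100000 nM, which is a limit of the assay.
Compound 2, `CCc1ccc(N2C(=O)C=CC2OCC(F)(F)F)cc1`, in this assay gives 8090 nM.

Compound 2 thus stands as the only numerical result in this assay; the other value shown is the limit of > 100000 nM in this assay, at which 1 of the 2 values shown sits. Compound 3, `CC(C)(C)c1ccc(N2C(=O)C=CC2OCC(F)(F)F)cc1`, has not yet been measured; it differs from compound 2 by tert-butyl in place of ethyl on an aromatic carbon. Among the measured compounds shown here, no step between measured compounds is available, so the size of this change cannot be read from the data. The step from compound 2 to compound 3 is expected to be small, about a 1.0-fold lower number from compound 2 to compound 3 (0.00 log units; within the scatter). Compound 3 is accordingly estimated at 8000 nM, with a range from 2500 nM to 25000 nM.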

Compound 3, half-maximal inhibitory concentration: 8500 nM
For compound 3 the middle estimate is 1.1-fold (0.03 log units) below the measured one; the range from low to high includes it.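

At this position, para to a large group, tert-butyl in place of ethyl brings 4 heavy atoms where there were 2, and in this assay the result is a 1.1-fold higher number from compound 2 to compound 3 (0.02 log units; within the scatter). Among the compounds shown here, this is the first step that can be read, and over these two alkyl groups the size of the group leaves the value unmoved beyond the scatter. Nothing shown here offers a cause for this result. On these data alone, whether an amine, a carboxylic acid or a longer chain in this place would give a similar value remains open.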